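Swapping Bromo for Methoxy on the Fused Ring

The source may report more compounds than this note shows. Statements on the series, on what has been measured and on what is new or still open speak of the compounds shown alone.

Of the compounds shown here, three have been measured. Compound 1 `COc1ccc(/C(Cl)=C/C=C(\C#N)C(=O)c2c(C)[nH]c3ccccc23)cc1` gives 74% in a functional assay for inhibition, read by Griess assay, with a stated time of 150 min, tested at 1 mM (a lower number here means less inhibition, a higher number more inhibition at the concentration tested (going by the name of the read-out)), compound 3 `COc1ccc(/C(Cl)=C/C=C(\C#N)C(=O)c2c[nH]c3ccccc23)cc1OC` gives 75%, and compound 2 `COc1ccc(/C(Cl)=C/C=C(\C#N)C(=O)c2c[nH]c3ccc(Br)cc23)cc1` gives 56.2%, the lowest of the three, with each of the other two values lying beyond the scatter above it. Compound 4 `COc1ccc(/C(Cl)=C/C=C(\C#N)C(=O)c2c[nH]c3ccc(OC)cc23)cc1` differs from compound 2 by a single change: methoxy in place of bromo on an aromatic carbon. For the measured compounds named here, no step between measured compounds isolates this change, so its effect is not directly known. Because compound 1 gives 74% and compound 3 gives 75% and neither carries a bromo, a modest upward step is expected, estimated at a number 8.8 percentage points higher from compound 2 to compound 4 (within the scatter). Compound 4 is therefore expected to give 65%, within a range from 45% to 82%.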

Compound 4, a percentage reported as inhibition, at one concentration (the size of the read-out at that concentration, not a potency): 41.6%
Beside the measured number, compound 4's estimate is 23.4 percentage points above it; measured number outside the range, below it.
By their numbers in this assay, from the lowest: compound 4; then compound 2; then compounds 1 and 3 (each within the scatter of the next).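

In this assay, methoxy in place of bromo on this aromatic carbon gives a number 14.6 percentage points lower from compound 2 to compound 4 (beyond the scatter). For the compounds shown here, this is the first step between compounds differing in one place, and it shows that the group on this carbon matters at the concentration tested, with the bromo compound giving the higher number; losing bromo does not by itself raise the inhibition here. Nothing at hand explains the direction of this step. On these data alone, whether an amine or a plain hydrogen on this carbon would match bromo or methoxy remains open.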